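This account rests on a few compounds, and the source may have more. Where it says the series, first, only, none or still open, it means among the compounds named here.

Measured so far:
- compound 1 `Cc1cc(NCc2ccccn2)n2ncc(-c3ccccc3F)c2n1`: 5000 nM
- compound 2 `CCN1CCCC1CNc1cc(C)nc2c(-c3ccccc3)c(C)nn12`: 172000 nM

Both numbers come from a physicochemical assay for solubility, read by HPLC, using the shake flask method, measured as kinetic solubility, with a stated time of 2 h, at pH 7.4; on this read-out lower numbers stand for lower solubility and higher numbers for higher solubility. In this assay compound 1 gives 5000 nM, the lower of the two values, while compound 2 gives 172000 nM, a gap that lies well beyond the scatter of the method. Among the compounds with values here, the two compounds differ in several places at once, so their values show only that compound 1 is the less soluble of the pair, not which change is responsible.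

The next compound, compound 3 `Cc1cc(NCc2ccccn2)n2ncc(-c3cncnc3)c2n1`, keeps the whole frame of compound 1 and changes a single group: pyrimidin-5-yl in place of 2-fluorophenyl on an aromatic carbon. Within the data shown here, no pair of measured compounds shows this exact change, so its effect has to be judged without a direct comparison. Taking compound 1 and its value of 5000 nM as the starting point, a moderate rise in solubility is expected, with the step of a 4.0-fold higher number from compound 1 to compound 3 (0.60 log units; beyond the scatter) estimated to reach beyond the scatter but not by a large margin. For compound 3 the expected result in this assay is 20000 nM, within a range from 5000 nM to 80000 nM.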

Compound 3, solubility: 111000 nM
Estimate against measurement, compound 3: 5.6-fold (0.74 log units) below; measured number outside the range, above it.
By their numbers in this assay, from the lowest: compound 1; then compounds 3 and 2 (each within the scatter of the next).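

Compounds 1 and 2 differ in several places at once, so their gap could not be tied to any one group. Compound 1 and compound 3 differ in one place only, and in this assay the exchange of 2-fluorophenyl for pyrimidin-5-yl on this aromatic carbon gives a 22-fold higher number from compound 1 to compound 3 (1.35 log units; beyond the scatter), a large step that belongs to this single change. The exchange alters several things together: a ring of carbon only with a fluorine gives way to a ring with 2 hetero atoms and 2 hydrogen-bond acceptors, and nothing shown here says which of these differences accounts for the step.

From the compounds shown here alone, what stays open is how the step divides between losing the fluorine and bringing nitrogen into the ring, which a group such as pyridin-3-yl, with a single ring nitrogen, at the same place could begin to separate. Also open, going by these compounds, is whether the same exchange gives a step of similar size when the side chain on the core is a different amine.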